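Series notes: trimethoxyphenyl replacement at the saturated carbon

The source may report more compounds than this note shows. Statements on the series, on what has been measured and on what is new or still open speak of the compounds shown alone.

Compound 1 `CS(=O)(=O)c1ccc(C2=NN(c3ccc(C(=O)O)cc3)C(c3ccc(F)cc3)C2)cc1` and compound 2 `CS(=O)(=O)c1ccc(C2=NN(c3ccc(S(N)(=O)=O)cc3)C(c3ccc(F)cc3)C2)cc1` share one core and have both been measured in a functional assay on the whole organism for inhibition, with Rattus norvegicus as the target, read by paw edema, with a stated time of 3 h, at a dose of 50 mg/kg by the oral route; on this read-out lower numbers stand for less inhibition and higher numbers for more inhibition at the one dose given (going by the name of the read-out). In that assay compound 1 gives 42.3%, and compound 2 gives 65.7%. Among the measured compounds shown here, the single step between them, a number 23.4 percentage points higher from compound 1 to compound 2 (beyond the scatter), places compound 2 highest of the two numbers known so far. Compound 3 `COc1cc(C2CC(c3ccc(S(C)(=O)=O)cc3)=NN2c2ccc(S(N)(=O)=O)cc2)cc(OC)c1OC` is not yet measured; it differs from compound 2 by 3,4,5-trimethoxyphenyl in place of 4-fluorophenyl on a saturated ring carbon. For the measured compounds named here, this change sits on a saturated ring carbon, whereas the only measured step concerned a group on an aromatic carbon, so no measured step bears on it and nothing known here gives its direction. The value of compound 3 in this assay is therefore expected to stay near the known numbers, with a wide range. The expected step is a number 7.7 percentage points lower from compound 2 to compound 3 (within the scatter). For compound 3 the estimate is 58%, between 35% and 80%.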

Compound 3, a percentage reported as inhibition, in the whole organism at one dose (the size of the read-out at that dose, not a potency): 73.7%
Beside the measured number, compound 3's estimate is 15.7 percentage points below it; the measured number falls inside the stated range.
By their numbers in this assay, from the lowest: compound 1; then compounds 2 and 3 (each within the scatter of the next).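

This is the only step shown at the saturated ring carbon: in this assay it reads a number 8 percentage points higher from compound 2 to compound 3 (within the scatter), so 3,4,5-trimethoxyphenyl, with 12 heavy atoms and 3 hydrogen-bond acceptors, replaces 4-fluorophenyl, with 7 heavy atoms and 0 acceptors, without a difference this read-out can separate. Among the compounds shown here, the position therefore accepts a clearly larger aryl group at this dose, whereas the sulfamoyl for carboxy change on the aromatic carbon remains the only step beyond the scatter, at a number 23.4 percentage points higher from compound 1 to compound 2 (beyond the scatter). Nothing available here speaks to why the two aryl groups read alike.

Going by these compounds, it remains open whether a non-aromatic group at the saturated ring carbon, such as an amine or a carboxylic acid on a short chain, would be accepted there. Also open, on these data alone, is whether the carboxy to sulfamoyl step holds with 3,4,5-trimethoxyphenyl in place.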